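The compounds below may be only part of what the source reports. "The series", "measured", "known", "first", "only" and "open" are said of these compounds alone.

Measured compounds:
Compound 1, `Cc1cc(N2CC[C@@H](C)[C@@H](N(C)c3ncnc4[nH]ccc34)C2)n2nc(SCc3csc4ccc(Cl)cc34)nc2n1`.
Compound 2, `Cc1cc(N2CC[C@@H](C)[C@@H](N(C)c3ncnc4[nH]ccc34)C2)n2nc(SCCc3ccccc3)nc2n1`.

In a functional assay on BGC-823 cells (Homo sapiens) for inhibition, read by MTT assay, with a stated time of 72 h (on this read-out lower numbers stand for stronger inhibition and higher numbers for weaker inhibition), compound 1 gives > 100000 nM, which is a limit of the assay and not a number. In this assay compound 2 gives 28000 nM. Compound 2 therefore holds the only number shown; the other value is a limit. Among the compounds with values here, the single measured step is an at least 3.5-fold lower number from compound 1 to compound 2 (0.55 log units; beyond the scatter), and because of the limit of > 100000 nM in this assay, at which 1 of the 2 values shown sits, its size is known only as a lower bound.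

Compound 3, `C#CSc1nc2nc(C)cc(N3CC[C@@H](C)[C@@H](N(C)c4ncnc5[nH]ccc45)C3)n2n1`, differs from compound 2 by ethynyl in place of phenethyl on a sulfur. The measured step changes the same sulfur but swaps one ring-bearing group for another, so it bears only loosely on this change. On that thin basis the expected step is a 1.4-fold higher number from compound 2 to compound 3 (0.15 log units; within the scatter), small against the scatter. Compound 3 is estimated at 40000 nM, within 10000 nM to 100000 nM.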

Compound 3, half-maximal inhibitory concentration: 62100 nM
For compound 3 the middle estimate is 1.6-fold (0.19 log units) below the measured one; the range from low to high includes it.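

Even ethynyl, with no ring, gives a measured number in this assay, so among these compounds a ring in the group on this sulfur is not required for a reading below the limit. Phenethyl now has a lower number than both other groups, with each step beyond the scatter: ethynyl in its place gives a 2.2-fold higher number from compound 2 to compound 3 (0.35 log units; beyond the scatter). Replacing (5-chloro-1-benzothiophen-3-yl)methyl with ethynyl gives an at least 1.6-fold lower number from compound 1 to compound 3 (0.20 log units; that floor lies within the scatter), a size known only as a floor because compound 1 stands at a limit: the limit of > 100000 nM in this assay, at which 1 of the 3 values shown sits.

Whether the ring or the chain of phenethyl accounts for its lower number stays open, since both leave together in this step. Also open, from the compounds shown here alone, is how a butyl chain, or a chain ending in an amine or a carboxylic acid, would read on this sulfur.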